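The compounds below may be only part of what the source reports. "The series", "measured", "known", "first", "only" and "open" are said of these compounds alone.

Measured compounds:
compound 1, `COc1cc(OC)c(/C=C/S(=O)(=O)Cc2cc(OC)c(OC)c(OC)c2)c(OC)c1`: > 20000 nM
compound 2, `COc1ccc(CS(=O)(=O)/C=C/c2ccc(F)cc2)cc1`: 1500 nM

In a functional assay on BT-20 cells (Homo sapiens) for antiproliferative activity, read by trypan blue exclusion (a higher number here means a weaker inhibitor, a lower number a stronger inhibitor), compound 1 gives only a limit, > 20000 nM. Going by the values given here, compound 2 is the one compound with a number in this assay, giving 1500 nM. Among the compounds with values here, the only other value shown, that of compound 1, is a limit, (the limit of > 20000 nM in this assay, at which 1 of the 2 values shown sits). Within the data shown here, there is thus no measured step against which to size a change. Compound 3, `COc1ccc(CS(=O)(=O)/C=C/c2ccc(N)cc2)cc1`, not yet measured, differs from compound 2 by amino in place of fluoro on an aromatic carbon, on a six-membered aromatic ring of carbon only, para to a large group, with one hydrogen-bond donor and one acceptor entering. Among the measured compounds shown here, with no comparable step measured, a modest step toward stronger inhibition is expected rather than one beyond the scatter, as a 2.5-fold lower number from compound 2 to compound 3 (0.40 log units; beyond the scatter). Compound 3 is therefore estimated at 600 nM, within a range of 100 nM to 3000 nM.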

Compound 3, half-maximal inhibitory concentration: > 20000 nM
Compound 3 was reported as a limit (the forecaster's own chance of this, stated with the estimate: 5%); middle value at least 33-fold (1.52 log units) away from the limit.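

In this assay, going by these compounds alone, the change from 4-fluorophenyl to 4-aminophenyl gives the first readable step, and it runs toward weaker inhibition: an at least 13-fold higher number from compound 2 to compound 3 (1.12 log units; beyond the scatter). This place, on an aromatic carbon para to a large group, is therefore not indifferent to what it carries, since exchanging one heavy atom for one heavy atom is enough to produce a large step. The value of compound 3 is a limit, so the step gives only a floor on the change: the limit of > 20000 nM in this assay, at which 2 of the 3 values shown sit.

A single pair cannot separate the leaving of the fluoro from the entering of the amino as the source of the step. Also open, going by these compounds, is how a chloro, a hydroxyl or an acetamide on this carbon would compare with compound 2, at 1500 nM.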